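Phenyl in place of a thiazolyl group on compound 1

The compounds below may be only part of what the source reports. "The series", "measured", "known", "first", "only" and "open" are said of these compounds alone.

Measured so far in a physicochemical assay for lipophilicity, at pH 7.4 (a lower number here means a more polar compound, a higher number a more lipophilic compound), for this series
- compound 1 `Cc1nc(C)c(-c2nnc(-c3ccc(OC(C)C)c(Cl)c3)s2)s1` at 7.76
- compound 2 `Cc1nn(-c2nnc(-c3ccc(OC(C)C)c(Cl)c3)s2)c(C)c1CCC(=O)O` at 4.3

Compound 1 stands highest of these two numbers, and compound 2, at 4.3 here, sits lower by a gap beyond the usual scatter. Compound 3 `CC(C)Oc1ccc(-c2nnc(-c3ccccc3)s2)cc1Cl` changes one place in compound 1: phenyl in place of 2,4-dimethyl-1,3-thiazol-5-yl on an aromatic carbon with phenyl in place of 2,4-dimethyl-1,3-thiazol-5-yl on an aromatic carbon. For the measured compounds named here, no measured pair shows this swap. Compound 1, at 7.76 and with no net charge, is the closest guide, and this assay is expected to show no step beyond the scatter. The estimate amounts to a number 0.04 log units higher from compound 1 to compound 3 (within the scatter) as the expected step. Compound 3 is estimated at 7.8 with 7.1 to 8.4 as the expected range.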

Compound 3, distribution coefficient: 8.65
Beside the measured number, compound 3's estimate is 0.85 log units below it; the measured number lies above the stated range.
By their numbers in this assay, from the lowest: compound 2; then compound 1; then compound 3.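

For the compounds shown here, replacing 2,4-dimethyl-1,3-thiazol-5-yl with phenyl gives a number 0.89 log units higher from compound 1 to compound 3 (beyond the scatter) in this assay and provides the only comparison here between compounds that differ in one place. It shows that changing the group on this aromatic carbon can move the number beyond the scatter, even though neither group carries a net charge. No measurement shown explains this step.

The compounds shown leave open how a pyridyl ring or an aminomethyl group at this position would read in this assay and whether the step would persist on a different core.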